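Compound 1 to compound 4: losing the 3,5-dichlorophenyl group

The source may hold more compounds than are shown below. What is called first, only, known or untested is meant among the compounds shown, and "the series" means these compounds.

In a functional assay on Vero cells (Chlorocebus sabaeus) for inhibition (on this read-out lower numbers stand for stronger inhibition and higher numbers for weaker inhibition), compound 1 (`COc1cc(/C=C/C(=O)c2cccc(NC(=O)c3cc(Cl)cc(Cl)c3)c2)ccc1O`) gives > 50 ug/mL, a limit of the assay and not a number. Compound 2 (`COc1cc(/C=C/C(=O)c2cccc(NC(=O)c3ccco3)c2)ccc1O`) gives 3.11 ug/mL and compound 3 (`COc1cc(/C=C/C(=O)c2cccc(NC(=O)C(C)C)c2)ccc1O`) gives 3.47 ug/mL. These two values lie within the scatter of each other: a 1.1-fold higher number from compound 2 to compound 3 (0.05 log units; within the scatter).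

Compound 4 (`COC(=O)C(=O)Nc1cccc(C(=O)/C=C/c2ccc(O)c(OC)c2)c1`) has not yet been measured. Its difference from compound 1 is methoxycarbonyl in place of 3,5-dichlorophenyl on a carbonyl carbon. In short, methoxycarbonyl stands in place of 3,5-dichlorophenyl on a carbonyl carbon.

Two measured steps remove the same group from the same place, and both are large: an at least 16-fold lower number from compound 1 to compound 2 (1.20 log units; beyond the scatter), and an at least 14-fold lower number from compound 1 to compound 3 (1.15 log units; beyond the scatter). Within the data shown here, both run towards lower numbers, and no measured compound goes against this, although the set holds only three compounds. Neither step starts from a number, so each gives only a minimum size. Methoxycarbonyl itself is untested here, which leaves the transfer from furan-2-yl and isopropyl uncertain and calls for a wide range.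

A large step of similar size towards a lower number is therefore expected: an at least 10-fold lower number from compound 1 to compound 4 (1.00 log units; beyond the scatter). Compound 4 is estimated at 5 ug/mL, with an expected range of 1.5 ug/mL to 20 ug/mL.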

Compound 4, half-maximal inhibitory concentration: 3.55 ug/mL
Estimate against measurement, compound 4: 1.4-fold (0.15 log units) above, within the range that was stated.
By their numbers in this assay, from the lowest: compounds 2, 3 and 4 (each within the scatter of the next). At a limit, above all of these: compound 1.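

Methoxycarbonyl joins furan-2-yl and isopropyl as a third group on this carbonyl carbon to give a large step in this assay: an at least 14-fold lower number from compound 1 to compound 4 (1.14 log units; beyond the scatter). The three replacements are not told apart at this position, with a 1.0-fold higher number from compound 3 to compound 4 (0.01 log units; within the scatter) and a 1.1-fold higher number from compound 2 to compound 4 (0.06 log units; within the scatter), so in this small set the read-out does not separate a ring, a plain alkyl group and an ester-bearing group. Compound 1 stands at a limit of the assay, so the steps from it give a minimum size only: the limit of > 50 ug/mL in this assay, at which 1 of the 4 values shown sits.

On these data alone, whether this level holds for an amine, a carboxylic acid or a longer chain on the same carbonyl carbon remains open. Also open, as far as these compounds go, is whether the high number of compound 1 goes with the phenyl ring itself or with its chlorine atoms, a question that a plain phenyl or a 3-chlorophenyl group at this place would address.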